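Swapping a Methylsulfanyl Group for Dimethylamino on a Nucleoside

A few compounds are considered here, and "the series" means these few. Any claim that something is new, unique, unknown or untested is made for them only; others in the source may bear on it.

Three nucleoside analogues sharing one fused core have been tested, and a fourth awaits its number. Compound 1 `CN(C)c1ncnc2c1c(-c1ccoc1)cn2[C@@H]1O[C@H](CO)[C@@H](O)[C@H]1O` carries a dimethylamino group and a furan-3-yl ring; compound 2 `CSc1ncnc2c1c(-c1ccoc1)cn2[C@@H]1O[C@H](CO)[C@@H](O)[C@H]1O` keeps the furan-3-yl ring but carries methylsulfanyl instead; compound 3 `CSc1ncnc2c1c(-c1cccs1)cn2[C@@H]1O[C@H](CO)[C@@H](O)[C@H]1O` keeps the methylsulfanyl group and carries a thiophen-2-yl ring. In an ADME assay on BJ cells (Homo sapiens), read by MTT assay, with a stated time of 72 h (a higher number here means a weaker inhibitor, a lower number a stronger inhibitor), compound 1 gives 99200 nM, compound 2 gives 98800 nM, and compound 3 gives 96900 nM. All three values sit within the usual scatter of one another, so none can be called stronger or weaker.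

The change from compound 2 to compound 1 is dimethylamino in place of methylsulfanyl on an aromatic carbon. It made a step of a 1.0-fold higher number from compound 2 to compound 1 (0.00 log units; within the scatter), a step within the scatter. The cores of compound 2 and compound 3 differ by thiophen-2-yl in place of furan-3-yl on an aromatic carbon, a change that made a step of a 1.0-fold lower number from compound 2 to compound 3 (0.01 log units; within the scatter), again within the scatter.

Compound 4 `CN(C)c1ncnc2c1c(-c1cccs1)cn2[C@@H]1O[C@H](CO)[C@@H](O)[C@H]1O` is not yet measured. It differs from compound 3 by dimethylamino in place of methylsulfanyl on an aromatic carbon, and the place of this change is described in exactly the same words as for the change from compound 2 to compound 1, so it is the same change applied on the thiophen-2-yl core. Because the earlier step was a 1.0-fold higher number from compound 2 to compound 1 (0.00 log units; within the scatter), the expected step in this assay is a 1.0-fold higher number from compound 3 to compound 4 (0.00 log units; within the scatter), essentially flat. Compound 4 is therefore estimated to give 97000 nM, with the range from 55000 nM to 170000 nM covering the ordinary spread of such readings.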

Compound 4, half-maximal inhibitory concentration: > 100000 nM
Compound 4: a limit, no number; the forecaster's own chance of this, stated with the estimate: 15%; middle value at least 1.0-fold (0.01 log units) from the limit.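

In this assay compound 4 gives > 100000 nM, which is a limit of the assay and not a number. On the thiophen-2-yl core, dimethylamino in place of methylsulfanyl gives an at least 1.0-fold higher number from compound 3 to compound 4 (0.01 log units; that floor lies within the scatter), so only a floor can be stated; this shows no sign on this core of a stronger inhibitor, but it does not show that the change behaves alike on both cores: the same change on two cores in this assay, a 1.0-fold higher number (0.00 log units; within the scatter) from compound 2 to compound 1 and an at least 1.0-fold higher number (0.01 log units; that floor lies within the scatter) from compound 3 to compound 4; the limit leaves it open whether they differ With the dimethylamino group in place, thiophen-2-yl in place of furan-3-yl gives a number no lower from compound 1 to compound 4 (the limit leaves the size open), so the size of this step cannot be read and the swap of the furan-3-yl ring for the thiophen-2-yl ring cannot be compared in size across the two cores: the same change on two cores in this assay, a 1.0-fold lower number (0.01 log units; within the scatter) from compound 2 to compound 3 and a number no lower (the limit leaves the size open) from compound 1 to compound 4; the limit leaves it open whether they differ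

Still open, as far as these compounds go, is whether a primary amine or a longer chain in place of dimethylamino on this aromatic carbon would give a step beyond the scatter. Also open, from the compounds shown here alone, is how the same swap would read on a core carrying a carboxylic acid in place of the thiophen-2-yl ring.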